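Swapping para-chloro for methyl on the aryl ring

This account rests on a few compounds, and the source may have more. Where it says the series, first, only, none or still open, it means among the compounds named here.

Three compounds share a core and were tested in a functional assay on SK-BR-3 cells (Homo sapiens) for inhibition, read by sulforhodamine B assay, with a stated time of 48 h; on this read-out lower numbers stand for stronger inhibition and higher numbers for weaker inhibition. Compound 1 `CO[C@@H]1CC=C2NN(c3cc(F)cc(Cl)c3)C(=O)C[C@]2(c2ccccc2)O1` gives 17600 nM. Going by the values given here, compound 2 `COc1ccc(N2NC3=CC[C@@H](OC)O[C@@]3(c3ccccc3)CC2=O)cc1` gives 8400 nM, and the step of a 2.1-fold lower number from compound 1 to compound 2 (0.32 log units; beyond the scatter) is the only measured one-point change in the set. Compound 3 `CO[C@@H]1CC=C2NN(c3ccc(Cl)cc3)C(=O)C[C@]2(C)O1` gives 28700 nM, the highest of the three numbers; against compound 1 the gap lies within the scatter, while against compound 2 it is beyond it.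

Compound 4 `CO[C@@H]1CC=C2NN(c3ccc(C)cc3)C(=O)C[C@]2(C)O1` is not yet measured. It differs from compound 3 by methyl in place of chloro on an aromatic carbon. Among the compounds with values here, no measured step touches exactly this exchange; the step from compound 1 to compound 2 alters the same aryl ring, but replaces a different pattern of substituents, so it bears only loosely and was itself modest. On this basis the number for compound 4 is expected to stay close to that of compound 3, with the step of a 1.1-fold lower number from compound 3 to compound 4 (0.06 log units; within the scatter) estimated to fall within the scatter. The estimate for compound 4 is 25000 nM, with a range from 10000 nM to 60000 nM.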

Compound 4, half-maximal inhibitory concentration: 29700 nM
Compound 4: middle estimate off by 1.2-fold (0.07 log units), on the low side; measured number inside the range.
By their numbers in this assay, from the lowest: compound 2; then compounds 1, 3 and 4 (each within the scatter of the next).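

In this assay, the exchange gives a 1.0-fold higher number from compound 3 to compound 4 (0.01 log units; within the scatter), so at this aromatic carbon, para to a large group, chloro and methyl cannot be told apart on this read-out. The earlier step from the aryl pattern of compound 1 to that of compound 2 changed several substituents at once, whereas this pair isolates a single group on the ring. No measurement here offers an explanation for this result.

The compounds shown leave open whether an amine or a carboxylic acid at this same carbon would also leave the number unchanged. They also leave open whether the exchange of chloro for methyl would read the same on a core carrying phenyl, as in compound 1, rather than the methyl of compound 3.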